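This account rests on a few compounds, and the source may have more. Where it says the series, first, only, none or still open, it means among the compounds named here.

Measured compounds:
- compound 1 `CCN(CC)Cc1c(O)ccc2oc(Cc3ccccc3)cc12`: 12000 nM
- compound 2 `CN(Cc1c(O)ccc2oc(Cc3ccccc3)cc12)C1CCCCC1`: 12000 nM
- compound 3 `Oc1ccc2oc(Cc3ccccc3)cc2c1CN1CCc2ccccc2C1`: 16000 nM

All three share one core and differ only in the amine attached to it. In a functional assay on SQ20B cells (Homo sapiens) for cytotoxicity, read by MTT assay, with a stated time of 72 h (a lower number here means a stronger inhibitor, a higher number a weaker inhibitor), compound 1 gives 12000 nM, and compound 2 gives 12000 nM, the same number at the digits shown. Compound 3, in which the amine is part of a fused ring system, gives 16000 nM in this assay, a number that reads slightly higher than compound 2 but still lies within the usual scatter, so the three compounds cannot be ranked against each other.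

Compound 4 `CN(Cc1ccccc1)Cc1c(O)ccc2oc(Cc3ccccc3)cc12` is not yet measured. It differs from compound 2 in one place: benzyl in place of cyclohexyl on an amine nitrogen. Within the data shown here, the only measured step that bears on this change is the one from compound 1 to compound 2, also a swap of groups on the amine nitrogen, which gave no change at the digits printed from compound 1 to compound 2 (within the scatter). Compound 3, with its differently built amine, sits in the same range. Among the measured compounds shown here, nothing measured so far suggests that changing the substituent on this nitrogen moves the number beyond the scatter.

For compound 4 the expected step is therefore no change at the digits printed from compound 2 to compound 4 (within the scatter), essentially no change. Compound 4 is estimated at 12000 nM in this assay, with a range from 6000 nM to 25000 nM.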

Compound 4, half-maximal inhibitory concentration: 12000 nM
Compound 4: the middle estimate sits on the measured number at the digits printed, and the stated range covers the measured number.
By their numbers in this assay, from the lowest: compounds 1, 2, 4 and 3 (each within the scatter of the next).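

In this assay, a benzyl group on the amine nitrogen in place of cyclohexyl gives no change at the digits printed from compound 2 to compound 4 (within the scatter) in this comparison, so a six-membered aromatic ring and a six-membered non-aromatic ring read alike at this place. The earlier step (no change at the digits printed from compound 1 to compound 2 (within the scatter)) exchanged only non-aromatic groups and could not show this. Set against the diethylamino compound, the benzyl(methyl)amino group gives no change at the digits printed from compound 1 to compound 4 (within the scatter) as well, so compounds 1, 2 and 4 form a flat set in which no step leaves the scatter, and nothing available here offers a reason for that flatness.

From the compounds shown here alone, all of these amines carry only carbon groups on the nitrogen, so it remains open whether a morpholine ring, a piperazine ring or a carboxylic acid on the benzyl ring would move the number beyond the scatter. Going by these compounds, whether the same flat reading holds when the shared core itself changes, for instance with a methoxy group in place of its hydroxyl group, also remains open.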